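A Saturated Ring in Place of a Chlorinated Aromatic One

The source may report more compounds than this note shows. Statements on the series, on what has been measured and on what is new or still open speak of the compounds shown alone.

The compounds here share one core and differ only in the group carried on an amine nitrogen. Compound 1 `O=C1C(Nc2cccc(Cl)c2)=CC(=O)c2c1nc1n2[C@H]2OC[C@@H](O)[C@H]2OC1` carries a 3-chlorophenyl there. In a functional assay on MCF7 cells (Homo sapiens) for inhibition, read by sulforhodamine B assay (on this read-out higher numbers stand for weaker inhibition and lower numbers for stronger inhibition), compound 1 gives 2970 nM. Compound 2 `O=C1C=C(Nc2ccccc2)C(=O)c2c1nc1n2[C@H]2OC[C@@H](O)[C@H]2OC1` carries a plain phenyl on the same nitrogen. In this assay compound 2 gives only a limit, > 4000 nM, not a number. For the measured compounds named here, compound 1 therefore stands as the only compound with a numerical result, while the other result sits at the limit of > 4000 nM in this assay, at which 1 of the 2 values shown sits.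

Compound 3 `O=C1C(NC2CCCCC2)=CC(=O)c2c1nc1n2[C@H]2OC[C@@H](O)[C@H]2OC1` is the unmeasured member. It differs from compound 1 in one place: cyclohexyl in place of 3-chlorophenyl on an amine nitrogen. Going by the values given here, no measured pair in this set shows what such a change does, so the expectation rests on the two values alone, and the near-limit position of compound 1 together with the limit of compound 2 suggests that this part of the molecule tolerates change poorly. The step from compound 1 to compound 3 is expected to be a 1.5-fold higher number from compound 1 to compound 3 (0.18 log units; within the scatter), toward weaker inhibition. In this assay compound 3 is estimated at 4500 nM, within a range from 1500 nM to 14000 nM.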

Compound 3, half-maximal inhibitory concentration: > 16000 nM
Compound 3 gave a limit, no number (the forecaster's own chance of this, stated with the estimate: 50%); middle value at least 3.5-fold (0.55 log units) away from the limit.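

Compound 3 gives only a limit of the assay, not a number: the limit of > 16000 nM in this assay, at which 1 of the 3 values shown sits. Even so, the change can be sized in this assay, where cyclohexyl in place of 3-chlorophenyl on the amine nitrogen is an at least 5.3-fold higher number from compound 1 to compound 3 (0.73 log units; beyond the scatter), toward weaker inhibition. For the compounds shown here, until now no step at this nitrogen could be read, and this one shows that the group carried there matters: two six-membered carbon rings, both with no hydrogen-bond donors or acceptors, are not interchangeable.

The step removes the chlorine and the aromatic ring together, so these compounds cannot tell which of the two loses the inhibition, and a comparison between a chlorine-free aromatic ring and cyclohexyl on this same core, with the amine in the same place, would be needed to separate them. Also open, from the compounds shown here alone, is how other groups on this nitrogen would behave, such as a benzyl group, whose aromatic ring stands one carbon further out, or an open butyl chain, which carries no ring at all.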